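The compounds below may be only part of what the source reports. "The series", "measured", "known", "first", "only" and "open" are said of these compounds alone.

Compound 1 `O=S(=O)(Oc1ccc(F)cc1)C1CC2OC1C(c1ccc(/C=C/c3cc(O)cc(O)c3)cc1)=C2c1ccc(O)cc1` gives 13100 nM
Compound 2 `O=S(=O)(Oc1ccc(-c2ccccc2)cc1)C1CC2OC1C(c1ccc(/C=C/c3cc(O)cc(O)c3)cc1)=C2c1ccc(O)cc1` gives 7800 nM

Both values come from a functional assay on MCF7 cells (Homo sapiens) for antiproliferative activity, read by MTT assay, with a stated time of 72 h (on this read-out lower numbers stand for stronger inhibition and higher numbers for weaker inhibition), and form the whole of the measured set. In this assay compound 2 at 7800 nM stands within the scatter of compound 1 at 13100 nM and so cannot be ranked against it.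

The next compound is compound 3 `Cc1ccc(OS(=O)(=O)C2CC3OC2C(c2ccc(/C=C/c4cc(O)cc(O)c4)cc2)=C3c2ccc(O)cc2)cc1` and the change from compound 2 is as follows: methyl in place of phenyl on an aromatic carbon (methyl in place of phenyl on an aromatic carbon, para to a large group, or 4-phenylphenyl to 4-methylphenyl). Among the compounds with values here, no measured compound yet carries methyl at this place. Within the data shown here, only one measured step bears on the change, phenyl in place of fluoro at the same place, which gave a 1.7-fold lower number from compound 1 to compound 2 (0.23 log units; within the scatter) and offers no sign of a large effect from that substituent. On that single step, no change beyond the scatter is expected in this assay when phenyl leaves. The expected step is a 1.4-fold higher number from compound 2 to compound 3 (0.15 log units; within the scatter) and this estimate carries little weight, as it rests on two values. For compound 3 the estimated value is 11000 nM with an expected range of 5000 nM to 24000 nM in this assay.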

Compound 3, half-maximal inhibitory concentration: 9200 nM
Compound 3: the middle estimate sits 1.2-fold (0.08 log units) above what was measured; measured number inside the range.
By their numbers in this assay, from the lowest: compounds 2, 3 and 1 (each within the scatter of the next).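

Going from 4-phenylphenyl to 4-methylphenyl in this assay gives a 1.2-fold higher number from compound 2 to compound 3 (0.07 log units; within the scatter), so taking away a whole six-membered aromatic ring at this place, para to a large group, leaves the number within the scatter, and the same holds for a group smaller than phenyl, not only for the swap of fluoro for phenyl seen earlier. The other new pair gives a 1.4-fold lower number from compound 1 to compound 3 (0.15 log units; within the scatter), so fluoro, methyl and phenyl at this aromatic carbon all stand within the scatter of one another in this assay, and the three compounds cannot be ranked. No supporting data bear on this flat result.

The compounds shown leave open whether an amine, a carboxylic acid or a longer chain such as n-butyl at this place would move the number beyond the scatter, as all three groups seen so far are carbon groups or fluoro. They also leave open whether changes elsewhere on the shared core, rather than at this aromatic carbon, are what shifts the number in this assay.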